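This account rests on a few compounds, and the source may have more. Where it says the series, first, only, none or still open, it means among the compounds named here.

Compound 1 `COc1cc(-c2nn(-c3cccc(NC(=O)c4cccc(C(F)(F)F)c4)c3)cc2-c2ccncc2)ccc1Cl` — in a functional assay on SF-539 cells (Homo sapiens) for inhibition, read by sulforhodamine B assay, with a stated time of 48 h (a lower number here means that less compound is tolerated, a higher number that more compound is tolerated), compound 1 gives > 50000 nM, a limit of the assay.
Compound 2 `COc1cc(-c2nn(-c3cccc(NC(=O)Nc4ccc(Cl)c(Cl)c4)c3)cc2-c2ccncc2)ccc1Cl` — in this assay compound 2 gives > 50000 nM, also a limit.
Compound 3 `COc1cc(-c2nn(-c3cccc(NC(=O)Nc4cccc(C(F)(F)F)c4)c3)cc2-c2ccncc2)ccc1Cl` — in this assay compound 3 gives 21000 nM.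

For the measured compounds named here, compound 3 thus holds the only real number in the set; the other two values sit at the limit of > 50000 nM in this assay, at which 2 of the 3 values shown sit. Compound 4 `COc1cc(-c2nn(-c3cccc(NC(=O)c4ccc(Cl)c(C(F)(F)F)c4)c3)cc2-c2ccncc2)ccc1Cl` differs from compound 3 by 4-chloro-3-(trifluoromethyl)phenyl in place of (3-(trifluoromethyl)phenyl)amino on a carbonyl carbon. The step that bears on this is an at least 2.3-fold lower number from compound 1 to compound 3 (0.37 log units; beyond the scatter), where replacing an aryl amide with the corresponding urea gave a lower number; compound 4 runs the same change in reverse, with an added chloro group. The expectation is therefore a step back upward, a 2.1-fold higher number from compound 3 to compound 4 (0.33 log units; beyond the scatter), quite possibly to the limit again. Compound 4 is estimated at 45000 nM, with a range from 15000 nM to 120000 nM.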

Compound 4, concentration lethal to 50% of the cells: > 32500 nM
Compound 4 gave a limit, no number; the forecaster's own chance of this, stated with the estimate: 55%; the middle value lies beyond the limit too.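

Compound 4 also ends in a limit, not a number: the limit of > 32500 nM in this assay, at which 1 of the 4 values shown sits. In this assay, for the compounds shown here, the only readable comparison is an at least 1.5-fold higher number from compound 3 to compound 4 (0.18 log units; that floor lies within the scatter), so this floor alone does not firmly separate 4-chloro-3-(trifluoromethyl)phenyl from (3-(trifluoromethyl)phenyl)amino on this carbonyl carbon. The steps to compound 4 from the other two compounds cannot be read, so the chloro in place of hydrogen has no readable size here.

Going by these compounds, the true value of compound 4 remains open. So does the outcome with an amine or a carboxylic acid in place of the trifluoromethyl group.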